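One stereocentre inverted in the series

The source may report more compounds than this note shows. Statements on the series, on what has been measured and on what is new or still open speak of the compounds shown alone.

Compound 1 `O=C(O)COc1cccc2c1CCC(COC(=O)N(c1ccccc1)c1ccccc1)=C2` gives 91 nM in a functional assay on cells (Cell line, plasma, Homo sapiens) for inhibition (on this read-out higher numbers stand for weaker inhibition and lower numbers for stronger inhibition), and compound 2 `O=C(O)COc1cccc2c1CC[C@H](COC(=O)N(c1ccccc1)c1ccccc1)[C@@H]2O` gives 170 nM on the same read-out, a pair within the usual scatter of each other. Compound 3 `O=C(O)COc1cccc2c1CC[C@H](COC(=O)N(c1ccccc1)c1ccccc1)[C@H]2O` is still unmeasured and carries the two compounds have the same atoms and bonds and differ only in configuration as drawn: 1 of 2 stereo elements differ; a stereocentre at a saturated ring carbon is drawn S in compound 2 and R in compound 3 relative to compound 2, with a stereocentre at a saturated ring carbon drawn S in compound 2 and R in compound 3. Among the compounds with values here, no measured pair shows such an inversion, so the direction remains open. In this assay the expected step is a 1.3-fold higher number from compound 2 to compound 3 (0.11 log units; within the scatter) and is estimated to stay within the scatter. For compound 3 the estimate is 220 nM with an expected range from 70 nM to 700 nM on this read-out.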

Compound 3, half-maximal inhibitory concentration: 3200 nM
Beside the measured number, compound 3's estimate is 15-fold (1.16 log units) below it; measured number above the stated range.
By their numbers in this assay, from the lowest: compounds 1 and 2 (each within the scatter of the next); then compound 3.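

In this assay, inverting the stereocentre at a saturated ring carbon from S to R gives a 19-fold higher number from compound 2 to compound 3 (1.27 log units; beyond the scatter). The step can be assigned to configuration alone, because nothing else separates the pair: the fact that compounds 2 and 3 differ only in the configuration as drawn. Within the data shown here, this stereocentre is therefore a sensitive point on this read-out, something the earlier compounds could not show.

The compounds shown leave open whether the S configuration would keep its advantage with an amine or a methoxy group in place of the ring hydroxyl. As far as these compounds go, the contribution of the second stereo element also remains open.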